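The compounds below may be only part of what the source reports. "The series", "measured", "known", "first", "only" and "open" are said of these compounds alone.

Three compounds share one core and differ only in the diamine chain attached to it. In an assay on HeLa cells for inhibition of sphingosine-1-phosphate transporter SPNS2 (Mus musculus), read by LC-MS, tested at 2 uM (on this read-out higher numbers stand for more inhibition at the one concentration tested (going by the name of the read-out) and lower numbers for less inhibition), compound 1 `CCCCCCCCCCc1ccc(-c2noc([C@@H](N)CCN)n2)cc1` gives 14%, compound 2 `CCCCCCCCCCc1ccc(-c2noc([C@@H](N)CCCN)n2)cc1` gives 40%, and compound 3 `CCCCCCCCCCc1ccc(-c2noc([C@H](N)CCCCN)n2)cc1` gives 50%. Compound 3 holds the highest of the three numbers; the step of a number 10 percentage points higher from compound 2 to compound 3 (within the scatter) is within the scatter, while a number 36 percentage points higher from compound 1 to compound 3 (beyond the scatter) and a number 26 percentage points higher from compound 1 to compound 2 (beyond the scatter) are beyond it, so lengthening the chain from compound 1 onward raised the read-out.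

Compound 4 `CCCCCCCCCCc1ccc(-c2noc(CCCN3CCCCC3)n2)cc1` takes a different turn: 3-(piperidin-1-yl)propyl in place of 1,5-diaminopentyl on an aromatic carbon. For the measured compounds named here, every measured step only lengthened a chain that kept both nitrogens; none removed a nitrogen or placed one in a ring, so no step covers this change directly. Going by the values given here, with the chain-length trend the only guide, and the amine pattern altered, a fall is expected, of about a number 25 percentage points lower from compound 3 to compound 4 (beyond the scatter) in this assay. Compound 4 is therefore estimated at 25%, with a range from 0% to 55%.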

Compound 4, a percentage reported as inhibition, at one concentration (the size of the read-out at that concentration, not a potency): 0%
Estimate against measurement, compound 4: 25 percentage points above; low and high end bracket the measured number.
By their numbers in this assay, from the lowest: compound 4; then compound 1; then compounds 2 and 3 (each within the scatter of the next).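

In this assay the move to 3-(piperidin-1-yl)propyl gives a number 50 percentage points lower from compound 3 to compound 4 (beyond the scatter) and a number 40 percentage points lower from compound 2 to compound 4 (beyond the scatter) and even a number 14 percentage points lower from compound 1 to compound 4 (beyond the scatter) so at this position the new group falls short of all three diamine chains, including the shortest. Length alone therefore does not set the read-out here, since this single change also removes the 2 hydrogen-bond donors and the defined stereocentre and places the one remaining nitrogen in a six-membered non-aromatic ring. No measurement shown here explains the loss or separates these features.

On these data alone, it remains open whether a 3-aminopropyl chain, ending in a primary amine without the ring, would restore the read-out. Equally open, as far as these compounds go, is whether a single amine on the carbon attached to the shared core would do the same.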